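The source may report more compounds than this note shows. Statements on the series, on what has been measured and on what is new or still open speak of the compounds shown alone.

Measured compounds:
Compound 1 `O=C(/C=C/c1ccc([N+](=O)[O-])cc1)Nc1cc(Sc2ncn[nH]2)c(O)c2ccccc12` gives in a functional assay on PC-3 cells (Homo sapiens) for antiproliferative activity, read by MTT assay, with a stated time of 48 h (on this read-out lower numbers stand for stronger inhibition and higher numbers for weaker inhibition), only a limit of the assay, > 100000 nM.
Compound 2 `O=C(Nc1cc(Sc2ncnc3nc[nH]c23)c(O)c2ccccc12)c1ccc(Cl)cc1` gives in this assay a value of 66400 nM.
Compound 3 `O=C(Nc1cc(Sc2ncn[nH]2)c(O)c2ccccc12)c1cccc(Cl)c1` gives in this assay a value of 85600 nM.

Of the two numbers in hand, compound 3 carries the higher one, but compound 2 lies within the usual scatter of it, so the two cannot be ranked against each other. The limit for compound 1 is the ceiling set out as the limit of > 100000 nM in this assay, at which 1 of the 3 values shown sits, and it adds no number to compare.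

Compound 4 `Cc1cccc(C(=O)Nc2cc(Sc3ncn[nH]3)c(O)c3ccccc23)c1` differs from compound 3 in a single place: methyl in place of chloro on an aromatic carbon. Going by the values given here, no measured pair in this set shows a change of this kind, so its size cannot be read from the data. The author expects the step of a 1.2-fold higher number from compound 3 to compound 4 (0.07 log units; within the scatter) to stay within the scatter, with no clear direction. Compound 4 is therefore estimated at 100000 nM, with a range from 30000 nM to 300000 nM, and a fair chance that the assay reports only a limit.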

Compound 4, half-maximal inhibitory concentration: 59500 nM
Compound 4: the middle estimate sits 1.7-fold (0.23 log units) above what was measured; the range from low to high includes it.
By their numbers in this assay, from the lowest: compounds 4, 2 and 3 (each within the scatter of the next). At a limit, above all of these: compound 1.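

Going by these compounds alone, with the 3-chlorophenyl group of compound 3 replaced by the 3-methylphenyl group of compound 4, a change at this position can be read for the first time: this assay gives a 1.4-fold lower number from compound 3 to compound 4 (0.16 log units; within the scatter). Chloro and methyl therefore cannot be told apart at this place on the ring, and no order can be set between the two compounds. Nothing in the data at hand bears on why this step is as small as it is.

Going by these compounds, what an amine, a carboxylic acid or a longer chain would do at this same place remains open. Also open, on these data alone, is whether methyl in place of chloro would give a step of similar size on the core of compound 2.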